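A Third Methoxy Group on the Carbonyl-Side Ring

The source may hold more compounds than are shown below. What is called first, only, known or untested is meant among the compounds shown, and "the series" means these compounds.

Compound 1 `COc1cc(-c2cc(/C=C/C(=O)c3ccc(N)cc3)[nH]n2)cc(OC)c1OC`: -22%
Compound 2 `COc1ccc(C(=O)/C=C/c2cc(-c3cc(OC)c(OC)c(OC)c3)n[nH]2)cc1OC`: -26%

Of the two measured compounds in a functional assay on CCRF-CEM cells (Homo sapiens) for cytotoxicity, read by sulforhodamine B assay, with a stated time of 48 h, tested at 10 uM (a lower number here means a stronger effect, a higher number a weaker effect of the compound at the concentration tested), compound 2 has the lowest number, with compound 1 close by; the step of a number 4 percentage points lower from compound 1 to compound 2 (within the scatter) lies within the scatter, so neither stands apart. Compound 3 `COc1cc(C(=O)/C=C/c2cc(-c3cc(OC)c(OC)c(OC)c3)n[nH]2)cc(OC)c1OC` differs from compound 2 by methoxy in place of hydrogen on an aromatic carbon. For the measured compounds named here, the only measured step, on the same ring attached to the carbonyl, changed nothing beyond the scatter, so the step of a number 1 percentage points higher from compound 2 to compound 3 (within the scatter) is expected to stay within it as well. For compound 3 the estimated value is -25%, with a range from -45% to -5%.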

Compound 3, a percentage reported as activity, at one concentration (the size of the read-out at that concentration, not a potency): -7%
Beside the measured number, compound 3's estimate is 18 percentage points below it; the measured number falls inside the stated range.
By their numbers in this assay, from the lowest: compounds 2 and 1 (each within the scatter of the next); then compound 3.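

In this assay, methoxy in place of hydrogen on this aromatic carbon gives a number 19 percentage points higher from compound 2 to compound 3 (beyond the scatter), a weaker effect at the concentration tested. For the compounds shown here, this is the first change on the ring attached to the carbonyl to go beyond the scatter, so this ring does respond to substitution. Nothing shown here accounts for the loss.

The compounds shown leave open whether the loss is specific to methoxy at this place. A hydroxyl group, an amine or a fluorine atom there could give a different result.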